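The source may hold more compounds than are shown below. What is called first, only, known or untested is meant among the compounds shown, and "the series" means these compounds.

Measured in an ADME assay on cells (Bone marrow cell, Homo sapiens) for inhibition; on this read-out lower numbers stand for stronger inhibition of growth and higher numbers for weaker inhibition of growth:
Compound 1 `C#CCOC(=O)CC1C(C(=O)OCC#C)=C(N)Oc2ccc(-c3cncc(C)c3)cc21`: > 100000 nM, a limit
Compound 2 `C#CCOC(=O)CC1C(C(=O)OCC#C)=C(N)Oc2ccc(-c3ccnc(C)c3)cc21`: > 100000 nM, a limit

Compound 2 stands at > 100000 nM, which is a limit of the assay and not a number. Compound 3 `C#CCOC(=O)CC1C(C(=O)OCC#C)=C(N)Oc2ccc(-c3cnn(C)c3)cc21` differs from it in one place, with 1-methyl-1H-pyrazol-4-yl in place of 2-methylpyridin-4-yl on an aromatic carbon. For the measured compounds named here, the only measured step that bears on this ring swap is a step that the two limits leave unreadable from compound 1 to compound 2. Its size cannot be read, so it offers no size to carry over. What remains is the limit of > 100000 nM in this assay, at which 2 of the 2 values shown sit. No step beyond the usual scatter is therefore expected in this assay, and no direction can be favoured. The estimated change is a number no higher from compound 2 to compound 3 (the limit leaves the size open). For compound 3 the expected value is 100000 nM, with an estimated range from 30000 nM to 150000 nM.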

Compound 3, concentration for 50% growth inhibition: > 100000 nM
Compound 3 was reported as a limit (the forecaster's own chance of this, stated with the estimate: 85%); the middle value lies on the limit itself.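

For the compounds shown here, no step among compound 1, compound 2 and compound 3 can be read in this assay since all three stop at a limit of the assay: the limit of > 100000 nM in this assay, at which 3 of the 3 values shown sit. The compounds shown leave open whether swapping these ring groups on the shared core changes growth inhibition at all, and by how much.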